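Swapping the aryl group on the triazole: cytotoxicity outlook

The source may report more compounds than this note shows. Statements on the series, on what has been measured and on what is new or still open speak of the compounds shown alone.

Measured so far:
- compound 1, `Cc1ccc(-n2cc(-c3ccccc3NS(=O)(=O)c3c[nH]c(=O)[nH]c3=O)nn2)cc1`: 32400 nM
- compound 2, `Cc1ccc(-n2cc(-c3cccc(NS(=O)(=O)c4c[nH]c(=O)[nH]c4=O)c3)nn2)cc1`: 15800 nM

Both compounds share one core and were tested in an ADME assay on GES1 cells (Homo sapiens) for cytotoxicity, read by MTT assay, with a stated time of 24 h; a higher number here means that more compound is tolerated, a lower number that less compound is tolerated. On that read-out compound 1 gives 32400 nM and compound 2 gives 15800 nM, so compound 2 stands as the lower of the two numbers, and the gap to compound 1 lies beyond the usual scatter of repeated measurements. For the measured compounds named here, no pair of measured compounds differs in only one place, so no single structural step has been followed yet.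

Compound 3, `O=c1[nH]cc(S(=O)(=O)Nc2cccc(-c3cn(-c4cccc(Cl)c4)nn3)c2)c(=O)[nH]1`, has not been measured. It differs from compound 2 in one place: 3-chlorophenyl in place of 4-methylphenyl on an aromatic nitrogen. Both groups are of the same size and carry no hydrogen-bond donors or acceptors. Going by the values given here, with no measured step of this kind to lean on, the expectation is cautious: the number for compound 3 is expected to stay close to that of compound 2, with a step of a 1.1-fold lower number from compound 2 to compound 3 (0.05 log units; within the scatter) that is not expected to go beyond the scatter. Compound 3 is therefore estimated at 14000 nM, with a range from 6000 nM to 35000 nM.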

Compound 3, half-maximal cytotoxic concentration: 26200 nM
Compound 3: the middle estimate sits 1.9-fold (0.27 log units) below what was measured; low and high end bracket the measured number.
By their numbers in this assay, from the lowest: compounds 2, 3 and 1 (each within the scatter of the next, the first and the last beyond it).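

For the compounds shown here, compound 2 to compound 3 is the first change that can be followed at a single place: on an aromatic nitrogen of the five-membered ring, in this assay, 3-chlorophenyl in place of 4-methylphenyl gives a 1.7-fold higher number from compound 2 to compound 3 (0.22 log units; within the scatter). This shows that one of these two aryl groups, each with 7 heavy atoms and one six-membered aromatic ring, can stand in for the other here without a change that can be told apart from the usual spread of repeated measurements. The swap alters both the substituent on the phenyl ring and where it sits, and nothing in the data explains the step or shows what either alteration does alone.

Either 4-chlorophenyl or 3-methylphenyl at this nitrogen would help separate those two alterations, since each shares one feature with compound 2 and one with compound 3. On these data alone, it also remains open whether the number would hold with something other than a substituted phenyl ring at this position, such as a plain benzyl group, a longer alkyl chain or a ring carrying an amine.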